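Taking the methoxy group off compound 2

The compounds below may be only part of what the source reports. "The series", "measured", "known", "first", "only" and "open" are said of these compounds alone.

In a functional assay on GC-1 cells (Mus musculus) for cytotoxicity, read by MTT assay, with a stated time of 72 h (a higher number here means a weaker inhibitor, a lower number a stronger inhibitor), compound 2 `COc1cccc(C(=O)c2sc(Nc3ccc(S(N)(=O)=O)cc3)nc2N)c1` gives 9100 nM and compound 1 `Nc1nc(Nc2ccc(S(N)(=O)=O)cc2)sc1C(=O)c1cccc(F)c1` gives 6400 nM and these two numbers lie within the usual scatter of each other. The two compounds therefore cannot be told apart on this evidence. The change from compound 2 to compound 3 `Nc1nc(Nc2ccc(S(N)(=O)=O)cc2)sc1C(=O)c1ccccc1` is hydrogen in place of methoxy on an aromatic carbon and amounts to hydrogen in place of methoxy on an aromatic carbon. Going by the values given here, only one measured step bears on it, an exchange of fluoro and methoxy at that same place on the ring. Because that exchange was a 1.4-fold higher number from compound 1 to compound 2 (0.15 log units; within the scatter) no step beyond the scatter is expected in this assay for this change, although a single step is thin support. The expected step is a 1.2-fold lower number from compound 2 to compound 3 (0.08 log units; within the scatter) on this estimate. Compound 3 is expected at 7500 nM with an estimated span from 3500 nM to 16000 nM as the likely range.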

Compound 3, half-maximal inhibitory concentration: 17000 nM
For compound 3 the middle estimate is 2.3-fold (0.36 log units) below the measured one, outside the stated range (above it).
By their numbers in this assay, from the lowest: compounds 1, 2 and 3 (each within the scatter of the next, the first and the last beyond it).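

In this assay, going by these compounds alone, removing the substituent at this place on the ring gives the first step here that clears the scatter, a 2.7-fold higher number from compound 1 to compound 3 (0.42 log units; beyond the scatter), which is a modest step and shows that fluoro and hydrogen can be told apart at this position. The step from methoxy to hydrogen, a 1.9-fold higher number from compound 2 to compound 3 (0.27 log units; within the scatter), stays within the scatter, so the same cannot be said of that change, and methoxy cannot be placed clearly apart from either fluoro or hydrogen. Nothing available here explains either step.

Going by these compounds, whether the gap between fluoro and hydrogen extends to other groups at this place remains open, for example a chloro, a hydroxyl or an amine. The compounds shown also cannot say whether a longer chain, such as ethoxy in place of methoxy, would separate from hydrogen.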